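A few compounds are considered here, and "the series" means these few. Any claim that something is new, unique, unknown or untested is made for them only; others in the source may bear on it.

Compound 2, with structure `COc1ccc(/C=N/Nc2ncc3c(n2)n(C2CCCC2)c(=O)c(=O)n3C)cc1`, was tested in a functional assay on PC-3 cells (Homo sapiens) for antiproliferative activity, read by MTT assay (on this read-out higher numbers stand for weaker inhibition and lower numbers for stronger inhibition), where compound 2 gives 26300 nM. Its only companion, compound 1, with structure `Cc1cc(C)c(/C=N/Nc2ncc3c(n2)n(C2CCCC2)c(=O)c(=O)n3C)c(C)c1`, gives 13900 nM in this assay; the two numbers lie within the scatter of each other, and compound 2 stands at the higher end of this small pair.

Compound 3, with structure `Cn1c(=O)c(=O)n(C2CCCC2)c2nc(N/N=C/c3ccc(F)cc3Br)ncc21`, has not yet been measured. It differs from compound 2 in one place: 2-bromo-4-fluorophenyl in place of 4-methoxyphenyl on a carbon with a double bond to nitrogen.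

For the measured compounds named here, the only measured step that bears on this change is the swap of one aromatic ring for another at the same carbon, from compound 1 to compound 2, which gave a 1.9-fold higher number from compound 1 to compound 2 (0.28 log units; within the scatter). That step stayed within the scatter, and nothing in the data speaks to a ring bearing bromine and fluorine in particular. The expectation for compound 3 is therefore no step beyond the scatter, a 1.2-fold lower number from compound 2 to compound 3 (0.08 log units; within the scatter), with an estimate near the present pair. Compound 3 is estimated at 22000 nM, with a likely range from 8000 nM to 60000 nM.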

Compound 3, half-maximal inhibitory concentration: 9250 nM
The estimate for compound 3 lay 2.4-fold (0.38 log units) above the measured number, and the stated range covers the measured number.
By their numbers in this assay, from the lowest: compounds 3, 1 and 2 (each within the scatter of the next, the first and the last beyond it).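

In this assay a change of ring on the carbon with a double bond to nitrogen now clears the usual scatter: 2-bromo-4-fluorophenyl in place of 4-methoxyphenyl is a modest step (a 2.8-fold lower number from compound 2 to compound 3 (0.45 log units; beyond the scatter)), whereas the earlier swap of one ring for another did not clear it. Putting the same 2-bromo-4-fluorophenyl ring in place of 2,4,6-trimethylphenyl gives a step that stays within the scatter (a 1.5-fold lower number from compound 1 to compound 3 (0.18 log units; within the scatter)), so compound 1 and compound 3 cannot be told apart, and the position responds measurably to the ring change only in the comparison with compound 2. No measurement at hand accounts for the size of either step, so both stand as plain observations.

Every ring shown at this carbon carries substituents, and it remains open whether bromine or fluorine alone, as in 2-bromophenyl or 4-fluorophenyl, would give the same reading as the two together. Also open, going by these compounds, is how this position would read with a ring bearing an amine or a carboxylic acid, or with a longer chain in place of the ring.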